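Shortening the carbamate chain on a selenocyanate

The compounds below may be only part of what the source reports. "The series", "measured", "known", "first", "only" and "open" are said of these compounds alone.

Measured so far:
- compound 1 `CCCCOC(=O)Nc1ccc([Se]C#N)cc1`: 8100 nM
- compound 2 `CCCCOC(=O)Nc1ccc([Se][Se]c2ccc(NC(=O)OCCCC)cc2)cc1`: 27600 nM

Of the compounds shown here, two have been tested in a functional assay on HT-29 cells (Homo sapiens) for cytotoxicity, read by MTT assay, with a stated time of 72 h; a lower number here means a stronger inhibitor of growth, a higher number a weaker inhibitor of growth. Compound 1 gives 8100 nM. Compound 2 gives 27600 nM. Compound 1 thus has the lower of the two numbers, and the gap to compound 2 lies beyond the scatter; with only these two, nothing more general can be read off.

Compound 3 `CCOC(=O)Nc1ccc([Se]C#N)cc1` is not yet measured. It differs from compound 1 in one place: hydrogen in place of ethyl on a saturated chain carbon, two bonds along the chain from an oxygen next to a carbonyl group. Among the compounds with values here, since no pair of measured compounds shows the effect of shortening this chain, the expectation rests on compound 1 alone. In this assay the step from compound 1 to compound 3 is expected to be a 1.4-fold higher number from compound 1 to compound 3 (0.13 log units; within the scatter), which is a change of about the size of the scatter, leaning towards a slightly higher number. Compound 3 is therefore estimated to give 11000 nM, with a likely range from 4000 nM to 30000 nM.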

Compound 3, concentration for 50% growth inhibition: 9300 nM
The estimate for compound 3 lay 1.2-fold (0.07 log units) above the measured number; low and high end bracket the measured number.
By their numbers in this assay, from the lowest: compounds 1 and 3 (each within the scatter of the next); then compound 2.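

In this assay, cutting butyl to ethyl on the carbamate chain of the selenocyanate gives a 1.1-fold higher number from compound 1 to compound 3 (0.06 log units; within the scatter), so the two compounds cannot be told apart. Within the data shown here, this is the first direct look at this position, and it shows that, for these two chains, the length of the chain makes no measurable difference to the number in this assay. Nothing available explains why the number holds across this change.

Going by these compounds, two chain lengths cannot establish a trend, so it remains open whether a much longer chain, such as octyl, would leave the number in the same range. On these data alone, it is equally open whether a shorter methyl, or a chain ending in an amine or a carboxylic acid, would do so.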